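The source may report more compounds than this note shows. Statements on the series, on what has been measured and on what is new or still open speak of the compounds shown alone.

Measured compounds:
compound 1, `N#Cc1c(Nc2ccc([N+](=O)[O-])cc2)sc2ccccc12`: 37%
compound 2, `N#Cc1c(Nc2cccc(O)c2)sc2ccccc12`: 60%

In a functional assay on HUVEC cells (Homo sapiens), read by fluorescence and microscopy, with a stated time of 6 h, tested at 250 nM (on this read-out higher numbers stand for a weaker effect at the one concentration tested and lower numbers for a stronger effect), compound 1 gives 37%, the lowest of the two numbers; compound 2 gives 60%, a gap beyond the scatter. Compound 3, `N#Cc1c(Nc2ccc(Cl)cc2)sc2ccccc12`, has not yet been measured. It differs from compound 1 by chloro in place of nitro on an aromatic carbon. Going by the values given here, no step between measured compounds isolates this change, so its size is open. The expected step is a number 9 percentage points higher from compound 1 to compound 3 (within the scatter), small and of uncertain direction, close to the scatter. Compound 3 is estimated at 46% in this assay, in the range 30% to 68%.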

Compound 3, a percentage reported as activity, at one concentration (the size of the read-out at that concentration, not a potency): 45%
Estimate against measurement, compound 3: 1 percentage points above; low and high end bracket the measured number.
By their numbers in this assay, from the lowest: compounds 1 and 3 (each within the scatter of the next); then compound 2.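

Chloro in place of nitro on an aromatic carbon, para to a large group, gives a number 8 percentage points higher from compound 1 to compound 3 (within the scatter) in this assay. At this position, then, a single chlorine atom with 0 hydrogen-bond acceptors can replace a nitro group with 2 hydrogen-bond acceptors without a shift beyond the scatter, so nitro is not needed to stay in this range. No supporting measurement is available to account for this result.

From the compounds shown here alone, whether an amine or a carboxylic acid at this position would stay in the same range remains open. Steps from compound 2 to the other two compounds cannot be read, so the effect of position on the ring also remains open.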